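Benzyl to 4-chlorobenzyl: a step on the sulfanyl arm

A few compounds are considered here, and "the series" means these few. Any claim that something is new, unique, unknown or untested is made for them only; others in the source may bear on it.

Of the compounds shown here, three of one series have been tested in a functional assay on the whole organism (artery, strain albino) with Rattus norvegicus as the target, with a stated time of 240 min, at a dose of 10 mg/kg by the oral route; a lower number here means less inhibition, a higher number more inhibition at the dose given (going by the name of the read-out). Compound 1 `COc1ccc(C2N=C(SCc3ccccc3Cl)NC(C)=C2C(=O)Nc2ccc(F)cc2)cc1OC` gives 30.3% in this assay. Compound 2 `CC1=C(C(=O)Nc2ccc(F)cc2)C(c2ccc([N+](=O)[O-])cc2)N=C(SCc2cccc(Cl)c2)N1` gives 15.9%, and compound 3 `CC1=C(C(=O)Nc2ccc(Br)cc2)C(c2ccc(Cl)cc2Cl)N=C(SCc2ccccc2)N1` gives 17.4%. Among these three numbers compound 3 stands second highest: the gap between compound 3 and compound 2 lies within the usual scatter of such measurements, so nothing can be said about their order, while compound 1 sits higher than compound 3 by a margin beyond that scatter.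

Compound 4 `CC1=C(C(=O)Nc2ccc(Br)cc2)C(c2ccc(Cl)cc2Cl)N=C(SCc2ccc(Cl)cc2)N1` has not yet been measured. Relative to compound 3, the difference is chloro in place of hydrogen on an aromatic carbon; read one bond further out, the benzylsulfanyl arm of compound 3 becomes a (4-chlorobenzyl)sulfanyl arm in compound 4. Among the measured compounds shown here, no pair of measured compounds differs by this change alone, so there is no direct precedent for its effect. The account therefore expects only a modest shift, a number 2.6 percentage points higher from compound 3 to compound 4 (within the scatter), not clearly beyond the scatter. Compound 4 is accordingly estimated at 20% in this assay, within a range from 8% to 35%.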

Compound 4, a percentage reported as inhibition, in the whole organism at one dose (the size of the read-out at that dose, not a potency): 32.3%
Compound 4: middle estimate off by 12.3 percentage points, on the low side; measured number inside the range.
By their numbers in this assay, from the lowest: compounds 2 and 3 (each within the scatter of the next); then compounds 1 and 4 (each within the scatter of the next).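

In this assay, the benzyl arm on sulfur proves sensitive to a single added atom: chloro in place of hydrogen on its aromatic carbon gives a number 14.9 percentage points higher from compound 3 to compound 4 (beyond the scatter). Among the compounds shown here, this is the first step that isolates one change, as the earlier compounds differ from one another in more than one place and could not separate the contribution of this arm from that of the rest of the structure. Nothing shown here accounts for the step, so its origin remains unknown.

The compounds shown leave open whether an amine or a carboxylic acid at this same place would also shift the number. They also leave open whether chloro would give a similar step with other groups elsewhere on the shared core.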